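Anilino variation on the shared core, step to compound 4

The source may hold more compounds than are shown below. What is called first, only, known or untested is meant among the compounds shown, and "the series" means these compounds.

Three compounds share one core and differ only in the aryl group on the nitrogen on an aromatic ring. In a functional assay on NCI-H1975 cells (Homo sapiens) for antiproliferative activity, read by MTT assay, with a stated time of 72 h (a higher number here means a weaker inhibitor, a lower number a stronger inhibitor), compound 1 `COc1cc2ncnc(Nc3ccc(Cl)c(C(F)(F)F)c3)c2cc1OCCCCC(=O)Nc1ccc(S(N)(=O)=O)cc1` gives 3220 nM. Compound 2 `COc1ccc(Nc2ncnc3cc(OC)c(OCCCCC(=O)Nc4ccc(S(N)(=O)=O)cc4)cc23)cc1` gives 30200 nM in this assay, and compound 3 `COc1cc2ncnc(Nc3cccc(C)c3)c2cc1OCCCCC(=O)Nc1ccc(S(N)(=O)=O)cc1` gives 32100 nM. The steps of a 9.4-fold higher number from compound 1 to compound 2 (0.97 log units; beyond the scatter) and a 10-fold higher number from compound 1 to compound 3 (1.00 log units; beyond the scatter) both lie beyond the scatter, whereas a 1.1-fold higher number from compound 2 to compound 3 (0.03 log units; within the scatter) lies within it, so compound 3 carries the highest number of the three but cannot be set apart from compound 2.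

Compound 4 `COc1cc2ncnc(Nc3ccc(C(F)(F)F)cc3)c2cc1OCCCCC(=O)Nc1ccc(S(N)(=O)=O)cc1` awaits measurement in this assay. The change from compound 3 is 4-(trifluoromethyl)phenyl in place of 3-methylphenyl on a nitrogen on an aromatic ring. Within the data shown here, no measured step makes exactly this exchange. The nearest bearing comes from compound 1, whose aryl group also carries a trifluoromethyl, through the step of a 10-fold higher number from compound 1 to compound 3 (1.00 log units; beyond the scatter). Compound 2 and compound 3, both without that group, sit close together. Compound 4 does not carry the chloro of compound 1, and the full step back is not assumed. The expectation for a 3.2-fold lower number from compound 3 to compound 4 (0.51 log units; beyond the scatter) is therefore a lower number, of a size beyond the scatter but short of the gap to compound 1. Compound 4 is estimated at 10000 nM, with a range from 3000 nM to 35000 nM.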

Compound 4, half-maximal inhibitory concentration: 12000 nM
Beside the measured number, compound 4's estimate is 1.2-fold (0.08 log units) below it, within the range that was stated.
By their numbers in this assay, from the lowest: compound 1; then compound 4; then compounds 2 and 3 (each within the scatter of the next).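

In this assay, the aryl group on the nitrogen now separates compounds that the earlier set could not: 4-(trifluoromethyl)phenyl gives a 2.7-fold lower number from compound 3 to compound 4 (0.43 log units; beyond the scatter) and a 2.5-fold lower number from compound 2 to compound 4 (0.40 log units; beyond the scatter), so compounds 2 and 3, which lie within the scatter of each other, both stand apart from compound 4. Compound 4 does not reach compound 1, with a 3.7-fold higher number from compound 1 to compound 4 (0.57 log units; beyond the scatter), so trifluoromethyl on the aryl group does not by itself go with the lowest number in the series, and the wide gap seen earlier now has an intermediate point. That last step removes the chloro and also changes where the trifluoromethyl sits, so it cannot be assigned to either change alone, and nothing available gives a cause for any of these steps.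

The compounds shown leave open how an aryl group carrying chloro alone, or a nitrile in place of trifluoromethyl, would compare with compound 4. They also leave open whether these aryl steps would hold with a longer chain, or with a carboxylic acid in place of the sulfonamide.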